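The source may report more compounds than this note shows. Statements on the series, on what has been measured and on what is new or still open speak of the compounds shown alone.

Compound 1, whose structure is `CCC(C)Oc1ccc(C(O)C2OC(=O)c3c(OC)cc(OC)cc32)cc1`, gives in an ADME assay on RAW264.7 cells (Mus musculus) for cytotoxicity, read by MTT assay, with a stated time of 24 h, in the presence of a further agent that is not named here (on this read-out lower numbers stand for stronger inhibition and higher numbers for weaker inhibition), only a limit of the assay: compound 1 shows > 40000 nM, which is a limit and not a number. Compound 2, `COCCCOc1ccc(C(O)C2OC(=O)c3c(OC)cc(OC)cc32)cc1`, also returns a limit in this assay, namely > 40000 nM. Compound 3, `COCCCCOc1ccc(C(O)C2OC(=O)c3c(OC)cc(OC)cc32)cc1`, likewise returns a limit in this assay, > 40000 nM. All three values therefore rest at the limit of > 40000 nM in this assay, at which 3 of the 3 values shown sit, so compound 1 stands at the same limit as the other two and none is ranked against another. The steps among them cannot be read: a step that the two limits leave unreadable from compound 1 to compound 2, a step that the two limits leave unreadable from compound 1 to compound 3 and a step that the two limits leave unreadable from compound 2 to compound 3. Compound 4, `COc1cc(OC)c2c(c1)C(C(O)c1ccc(OCc3ccc(OC(F)F)cc3)cc1)OC2=O`, differs from compound 1 by 4-(difluoromethoxy)benzyl in place of sec-butyl on an oxygen on an aromatic ring. The measured steps that change the same oxygen, those from compound 1 to compounds 2 and 3, bear on this change, but their size is not readable, so no direction can be drawn from them. Compound 4 is therefore expected to stay at the limit, a step that the limit leaves unreadable from compound 1 to compound 4, and its estimated value in this assay is 50000 nM, between 15000 nM and 150000 nM.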

Compound 4, half-maximal inhibitory concentration: > 40000 nM
Compound 4 ended at the assay's limit (the forecaster's own chance of this, stated with the estimate: 75%); the middle value does not contradict the limit.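

In this assay compound 4 gives > 40000 nM, which is a limit and not a number. Its steps from compound 1, compound 2 and compound 3 therefore cannot be read: the limit of > 40000 nM in this assay, at which 4 of the 4 values shown sit. The compounds shown leave open whether any of these changes on the oxygen on the aromatic ring shifts the value in this assay at all.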